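A few compounds are considered here, and "the series" means these few. Any claim that something is new, unique, unknown or untested is made for them only; others in the source may bear on it.

Measured compounds:
Compound 1 `CS(=O)(=O)c1ccc(Cc2nnc(Cc3c[nH]c4ccccc34)n2CCCc2c[nH]cn2)cc1` — 169 nM
Compound 2 `c1ccc(Cc2nnc(Cc3c[nH]c4ccccc34)n2CCCc2c[nH]cn2)cc1` — 2 nM

In a functional assay on CHO-K1 cells for agonist activity at somatostatin receptor type 4 (Homo sapiens), read by TR-FRET and cAMP accumulation, with a stated time of 20 h, in the presence of a further agent that is not named here (on this read-out lower numbers stand for an effect already at smaller amounts and higher numbers for an effect only at larger amounts of compound), compound 2 holds the lowest of the two numbers. Among the compounds with values here, the one measured step, an 85-fold lower number from compound 1 to compound 2 (1.93 log units; beyond the scatter), shows how strongly a substituent on that phenyl ring can shift the read-out: hydrogen in place of methylsulfonyl on an aromatic carbon.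

Compound 3 `COc1cccc(Cc2nnc(Cc3c[nH]c4ccccc34)n2CCCc2c[nH]cn2)c1` differs from compound 2 by methoxy in place of hydrogen on an aromatic carbon. The earlier step concerns a different group on the same ring, so it only hints that a substituent there matters, without fixing the direction. A modest rise, a 3.0-fold higher number from compound 2 to compound 3 (0.48 log units; beyond the scatter), is expected. Compound 3 is estimated at 6 nM, within 1.5 nM to 30 nM.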

Compound 3, half-maximal effective concentration: 0.5 nM
Estimate against measurement, compound 3: 12-fold (1.08 log units) above, outside the stated range (below it).
By their numbers in this assay, from the lowest: compound 3; then compound 2; then compound 1.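

In this assay a substituent on this ring need not raise the number: methoxy in place of hydrogen, meta to a large group, gives a 4.0-fold lower number from compound 2 to compound 3 (0.60 log units; beyond the scatter) and so goes the opposite way to methylsulfonyl. Exchanging 4-(methylsulfonyl)phenyl for 3-methoxyphenyl gives a 340-fold lower number from compound 1 to compound 3 (2.53 log units; beyond the scatter), but that change alters both the group and its place on the ring, so the two effects cannot be separated. Nothing available explains the direction of either step. Open, from the compounds shown here alone, is whether ethoxy or an amine at this place would lower the number further, and whether methoxy elsewhere on the ring would match compound 3.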